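Anilino ring substituent swap in a weakly cytotoxic series

The source may hold more compounds than are shown below. What is called first, only, known or untested is meant among the compounds shown, and "the series" means these compounds.

Measured in a functional assay on COLO 205 cells (Homo sapiens) for cytotoxicity, read by MTT assay, with a stated time of 48 h; a lower number here means a stronger inhibitor, a higher number a weaker inhibitor:
Compound 1 `COc1ccc(Nc2nc(-c3cccc(F)c3)nc3ccc(F)cc23)cc1`: 46800 nM
Compound 2 `Fc1cccc(-c2nc(Nc3ccc(Cl)cc3)c3cc(F)ccc3n2)c1`: 32600 nM
Compound 3 `Oc1ccc(Nc2nc(-c3cccc(F)c3)nc3ccc(F)cc23)cc1`: > 50000 nM

The value for compound 3 is a limit of this assay, (the limit of > 50000 nM in this assay, at which 1 of the 3 values shown sits). Compound 3 stands beside compounds 1 and 2 rather than apart from them: an at least 1.0-fold higher number from compound 1 to compound 3 (0.02 log units; that floor lies within the scatter) and an at least 1.5-fold higher number from compound 2 to compound 3 (0.18 log units; that floor lies within the scatter) both lie within the scatter, and a 1.4-fold lower number from compound 1 to compound 2 (0.16 log units; within the scatter) does too, so the three measured numbers show no ordering.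

Compound 4 `Nc1cccc(Nc2nc(-c3cccc(F)c3)nc3ccc(F)cc23)c1` differs from compound 3 by 3-aminophenyl in place of 4-hydroxyphenyl on a nitrogen on an aromatic ring. Within the data shown here, no measured step exchanges an amino group for a hydroxy group on this ring, and every measured step in this assay stays within the scatter, so no step beyond the scatter is expected here either. Compound 4 is therefore expected to give 45000 nM (estimated range 18000 nM to 150000 nM), an expected step of an at least 1.1-fold lower number from compound 3 to compound 4 (0.04 log units; that floor lies within the scatter) that may well again be reported only as a limit.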

Compound 4, half-maximal inhibitory concentration: > 50000 nM
Compound 4 ended at the assay's limit (the forecaster's own chance of this, stated with the estimate: 50%); middle value at least 1.1-fold (0.04 log units) away from the limit.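

In this assay compound 4, like compound 3, is held only as a limit, so the step between those two cannot be read: the limit of > 50000 nM in this assay, at which 2 of the 4 values shown sit.

The readable steps are an at least 1.5-fold higher number from compound 2 to compound 4 (0.18 log units; that floor lies within the scatter) and an at least 1.0-fold higher number from compound 1 to compound 4 (0.02 log units; that floor lies within the scatter), so 3-aminophenyl on this nitrogen does not separate from 4-chlorophenyl or 4-methoxyphenyl. Changing the group and its place on the ring together therefore still yields no ordering in this set.

Open, from the compounds shown here alone, is whether the amino group alone or its place on the ring matters, which 4-aminophenyl would address. Also open, going by these compounds, is whether a carboxylic acid or a longer chain on this ring would give a value clear of the limit.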